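Aryl swap on the carbonyl carbon: compound 3 to compound 4

The source may report more compounds than this note shows. Statements on the series, on what has been measured and on what is new or still open speak of the compounds shown alone.

Three compounds share one core and differ only in the aryl group on the carbonyl carbon. In an assay on CHO cells for displacement of a labelled ligand from adenosine receptor A3 (Homo sapiens), read by scintillation counting (on this read-out higher numbers stand for weaker inhibition and lower numbers for stronger inhibition), compound 1 `O=C(Nc1nc(-c2ccccc2)nc2c1nnn2Cc1ccccc1)c1cccc(F)c1` gives 5810 nM; compound 2 `O=C(Nc1nc(-c2ccccc2)nc2c1nnn2Cc1ccccc1)c1cccc([N+](=O)[O-])c1` gives 4850 nM; compound 3 `O=C(Nc1nc(-c2ccccc2)nc2c1nnn2Cc1ccccc1)c1ccccc1F` gives 5300 nM. On these numbers compound 3 stands second highest of the three, though its gaps to compound 2 and compound 1 are within the scatter. Compound 4 `Nc1ccc(C(=O)Nc2nc(-c3ccccc3)nc3c2nnn3Cc2ccccc2)cc1` carries 4-aminophenyl in place of 2-fluorophenyl on a carbonyl carbon. Among the compounds with values here, the steps that bear on it, a 1.1-fold lower number from compound 1 to compound 3 (0.04 log units; within the scatter), a 1.1-fold higher number from compound 2 to compound 3 (0.04 log units; within the scatter) and a 1.2-fold lower number from compound 1 to compound 2 (0.08 log units; within the scatter), each alter the aryl group on the carbonyl carbon without moving the number beyond the scatter. Within the data shown here, no measured step tests a 4-aminophenyl group, so no step beyond the scatter is expected in this assay. For compound 4 the estimate is 5000 nM, range 2000 nM to 15000 nM, which is a 1.1-fold lower number from compound 3 to compound 4 (0.03 log units; within the scatter).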

Compound 4, inhibition constant: 926 nM
Estimate against measurement, compound 4: 5.4-fold (0.73 log units) above, outside the stated range (below it).
By their numbers in this assay, from the lowest: compound 4; then compounds 2, 3 and 1 (each within the scatter of the next).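

In this assay the aryl group on the carbonyl carbon is no longer silent: 4-aminophenyl gives a 5.7-fold lower number from compound 3 to compound 4 (0.76 log units; beyond the scatter) and a 5.2-fold lower number from compound 2 to compound 4 (0.72 log units; beyond the scatter) and also a 6.3-fold lower number from compound 1 to compound 4 (0.80 log units; beyond the scatter) while the swaps among 2-fluorophenyl, 3-fluorophenyl and 3-nitrophenyl all stayed within the scatter. So this position can move the number, and so far only 4-aminophenyl has moved it beyond the scatter. Nothing available explains this step. From the compounds shown here alone, it remains open whether the amine itself carries the step or where it sits on the ring. An unsubstituted phenyl, a 4-hydroxyphenyl or an acylated amine would separate these readings.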